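Removing three chain carbons on a shared core

The compounds below may be only part of what the source reports. "The series", "measured", "known", "first", "only" and "open" are said of these compounds alone.

Of the compounds shown here, three have been tested in a functional assay on COLO 205 cells (Homo sapiens) for cytotoxicity, read by MTT assay, with a stated time of 24 h; on this read-out lower numbers stand for stronger inhibition and higher numbers for weaker inhibition. Compound 1 `CCCCCCCCCCn1cc(-c2nc3ccccc3cc2C)nn1` gives 44.5 ug/mL. For compound 2 `CCCCCCCCCCn1cc(-c2nc3ccccc3cc2CCCC)nn1` the assay reports only a limit, > 100 ug/mL. The two differ by hydrogen in place of propyl on a saturated chain carbon bound to an aromatic carbon, and that change gives an at least 2.2-fold lower number from compound 2 to compound 1 (0.35 log units; beyond the scatter); the size of this step can only be bounded, since it starts from the limit of > 100 ug/mL in this assay, at which 2 of the 3 values shown sit.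

Compound 3 `CCCCCc1cc2ccccc2nc1-c1cn(-c2ccc(F)cc2)nn1` likewise returns only a limit in this assay, > 100 ug/mL. The difference between the core of compound 3 and the core of compound 2 is not broken down here.

Compound 4 `CCc1cc2ccccc2nc1-c1cn(-c2ccc(F)cc2)nn1` has not yet been measured. It differs from compound 3 by hydrogen in place of propyl on a saturated chain carbon, two bonds along the chain from an aromatic carbon. For the measured compounds named here, this is the same kind of change as the one from compound 2 to compound 1, though not the same one: in the earlier pair the saturated chain carbon is bound to an aromatic carbon, whereas in compound 3 and compound 4 it sits two bonds along the chain from an aromatic carbon.

On the strength of that earlier pair, where the change produced an at least 2.2-fold lower number from compound 2 to compound 1 (0.35 log units; beyond the scatter), a step of an at least 1.6-fold lower number from compound 3 to compound 4 (0.22 log units; that floor lies within the scatter) is expected from compound 3 to compound 4. Because the starting point is the limit of > 100 ug/mL in this assay, at which 2 of the 3 values shown sit, this expectation is loose, and compound 4 may well again return only a limit. Compound 4 is estimated at 60 ug/mL, with a likely range from 25 ug/mL to 150 ug/mL.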

Compound 4, half-maximal inhibitory concentration: > 100 ug/mL
Compound 4: only a limit was reported; the forecaster's own chance of this, stated with the estimate: 40%; middle value at least 1.6-fold (0.22 log units) away from the limit.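

In this assay compound 4 returns only a limit (> 100 ug/mL), as compound 3 did. No step can be read from compound 3 to compound 4, because both stand at a limit: the limit of > 100 ug/mL in this assay, at which 3 of the 4 values shown sit. The compounds shown leave open whether the change from pentyl to ethyl on this core alters the read-out at all.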